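Lengthening the Alkyl Chain of Compound 1

This account rests on a few compounds, and the source may have more. Where it says the series, first, only, none or still open, it means among the compounds named here.

Compound 1 `CCCCc1cc2cn(COCCO)c(=O)nc2o1`: > 200000 nM (a limit)
Compound 2 `CCCCCCCCCCCc1cc2cn(COCCO)c(O)nc-2n1`: 41000 nM
Compound 3 `CCCCC#Cc1cc2cn(COCCO)c(=O)nc2o1`: > 50000 nM (a limit)

In a functional assay on HEL cells (Homo sapiens) (on this read-out higher numbers stand for lower toxicity in this test and lower numbers for higher toxicity in this test), compound 1 gives > 200000 nM, which is a limit and not a number. Compound 3 gives > 50000 nM, which is also a limit. Compound 4 `CCCCCCCCc1cc2cn(COCCO)c(=O)nc2o1` differs from compound 1 by butyl in place of hydrogen on a saturated chain carbon, four bonds along the chain from an aromatic carbon.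

For the measured compounds named here, the only measured step on this chain, a step that the two limits leave unreadable from compound 1 to compound 3, has no readable size, so it offers no direct guide. Going by the values given here, compound 2, with a longer chain on a different core, gives 41000 nM in this assay, the only exact number available. On the strength of compound 2 at 41000 nM, a move toward lower numbers, meaning higher toxicity, is expected. A result reported only as a limit remains quite possible for compound 4. The expected step is an at least 2.5-fold lower number from compound 1 to compound 4 (0.39 log units; beyond the scatter). For compound 4 the estimated value is 80000 nM, with an expected range of 25000 nM to 200000 nM.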

Compound 4, half-maximal cytotoxic concentration: > 200000 nM
Compound 4: only a limit was reported (the forecaster's own chance of this, stated with the estimate: 50%); middle value at least 2.5-fold (0.39 log units) away from the limit.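

In this assay compound 4 gives > 200000 nM, which is a limit. Compound 1 gives > 200000 nM, also a limit, so the step between these two compounds cannot be read. The compounds shown leave open whether butyl in place of hydrogen at this place changes the half-maximal cytotoxic concentration at all.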